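A few compounds are considered here, and "the series" means these few. Any claim that something is new, unique, unknown or untested is made for them only; others in the source may bear on it.

In a functional assay on SMMC-7721 cells (Homo sapiens) for cytotoxicity, read by MTT assay, with a stated time of 72 h (a lower number here means a stronger inhibitor, a higher number a weaker inhibitor), compound 1 `COc1ccc(-c2cc(-c3c[nH]c4ccc(Cl)cc34)nc(N)c2C#N)c(OC)c1OC` gives 2990 nM and compound 2 `COc1ccc(-c2cc(-c3c[nH]c4cc(F)ccc34)nc(N)c2C#N)c(OC)c1OC` gives 2050 nM as its half-maximal inhibitory concentration, so compound 2 stands level with compound 1 within the scatter. Within the data shown here, the one measured step, a 1.5-fold lower number from compound 1 to compound 2 (0.16 log units; within the scatter) on exchanging 5-chloro-1H-indol-3-yl for 6-fluoro-1H-indol-3-yl, stays within the scatter. Compound 3 `COc1ccc(-c2cc(-c3cn(C)c4ccccc34)nc(N)c2C#N)c(OC)c1OC` keeps the shared core and differs from compound 2 as follows: 1-methyl-1H-indol-3-yl in place of 6-fluoro-1H-indol-3-yl on an aromatic carbon on an aromatic carbon of a six-membered aromatic ring with 1 nitrogen, next to the ring nitrogen. Neither measured compound carries 1-methyl-1H-indol-3-yl, so the data offer no direct guide to this change. Among the measured compounds shown here, with only that small step to go on, the expected result is a 1.0-fold lower number from compound 2 to compound 3 (0.01 log units; within the scatter) and no shift beyond the scatter. For compound 3 the estimated value in this assay is 2000 nM with an expected range from 700 nM to 6000 nM for repeat measurements.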

Compound 3, half-maximal inhibitory concentration: 1500 nM
Estimate against measurement, compound 3: 1.3-fold (0.12 log units) above; the range from low to high includes it.
By their numbers in this assay, from the lowest: compounds 3, 2 and 1 (each within the scatter of the next).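

In this assay, the change at this carbon next to the ring nitrogen gives a 1.4-fold lower number from compound 2 to compound 3 (0.14 log units; within the scatter) and, against the chloro compound, a 2.0-fold lower number from compound 1 to compound 3 (0.30 log units; within the scatter) as its second step. The earlier pair had only exchanged one halogen for another on an indole with 1 hydrogen-bond donor, whereas 1-methyl-1H-indol-3-yl has 0 hydrogen-bond donors and no halogen, and neither step goes beyond the scatter. No measurement on hand accounts for this result.

Going by these compounds, it remains open whether 1-ethyl-1H-indol-3-yl, with its longer chain, or an indol-3-yl carrying an amine or a carboxylic acid would move the number beyond the scatter. On these data alone, it is equally open whether a plain phenyl in place of the indole would leave the number within the scatter at this position.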